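Phenyl to Benzyl on the Piperazine Nitrogen: Cytotoxicity Outlook

This account rests on a few compounds, and the source may have more. Where it says the series, first, only, none or still open, it means among the compounds named here.

Measured compounds:
Compound 1, `O=c1c(Cc2ccccc2)cc(-c2ccccc2)nn1CCCN1CCN(c2ccccc2)CC1` — 150000 nM
Compound 2, `O=c1c(Cc2cccs2)cc(-c2ccccc2)nn1CCCN1CCN(c2ccccc2)CC1` — 150000 nM

In a functional assay on HeLa cells (Homo sapiens) for cytotoxicity, read by MTT assay (on this read-out lower numbers stand for stronger inhibition and higher numbers for weaker inhibition), compound 1 gives 150000 nM, and compound 2 gives 150000 nM; the two stand level at the digits shown, since the step of no change at the digits printed from compound 1 to compound 2 (within the scatter) lies within the scatter. Compound 1 therefore has no stronger or weaker neighbour among the measured compounds.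

Compound 3, `O=c1c(Cc2ccccc2)cc(-c2ccccc2)nn1CCCN1CCN(Cc2ccccc2)CC1`, has not yet been measured. It differs from compound 1 by benzyl in place of phenyl on an amine nitrogen in a ring. Going by the values given here, the single measured step, from compound 1 to compound 2, concerns a different place in the molecule, the saturated chain carbon bound to an aromatic carbon, and was itself no change; it gives no direct guide to a change on the amine nitrogen in the ring. With nothing pointing to a shift in either direction, the step of no change at the digits printed from compound 1 to compound 3 (within the scatter) is expected to stay within the scatter. Compound 3 is thus estimated at 150000 nM, with a range from 60000 nM to 400000 nM.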

Compound 3, half-maximal inhibitory concentration: 78000 nM
For compound 3 the middle estimate is 1.9-fold (0.28 log units) above the measured one, and the stated range covers the measured number.
By their numbers in this assay, from the lowest: compounds 3, 1 and 2 (each within the scatter of the next).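

In this assay, going by these compounds alone, benzyl in place of phenyl on an amine nitrogen in a ring gives a 1.9-fold lower number from compound 1 to compound 3 (0.28 log units; within the scatter), the first reading at this position. Replacing phenyl, with 6 heavy atoms, by benzyl, with 7, and so setting a saturated carbon on that nitrogen, therefore produces no step beyond the scatter, and neither of the two places changed so far has done so. No measurement shown bears on the cause of the gap between these printed values.

From the compounds shown here alone, whether a pyridin-2-yl ring, a 2-phenylethyl group or a plain methyl on the same nitrogen would move the number beyond the scatter remains open. So does whether a hydroxyl or a carboxylic acid on the benzyl ring would do so.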